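The source may report more compounds than this note shows. Statements on the series, on what has been measured and on what is new or still open speak of the compounds shown alone.

Compound 1 `Cc1cccc(/C=N/Nc2ncc3c(n2)n(C2CCCC2)c(=O)c(=O)n3C)c1`: > 100000 nM in a functional assay on HCT-116 cells (Homo sapiens) for antiproliferative activity, read by MTT assay (a lower number here means a stronger inhibitor, a higher number a weaker inhibitor), a limit of the assay.
Compound 2 `Cn1c(=O)c(=O)n(C2CCCC2)c2nc(N/N=C/c3ccc(F)c(Cl)c3)ncc21`: 9020 nM in this assay.

Compound 1 stands at the limit (the limit of > 100000 nM in this assay, at which 1 of the 2 values shown sits), so its number is bounded, not known. Compound 3 `Cn1c(=O)c(=O)n(C2CCCC2)c2nc(N/N=C/c3cccc(Cl)c3Cl)ncc21` differs from compound 1 in one place (2,3-dichlorophenyl in place of 3-methylphenyl on a carbon with a double bond to nitrogen). Among the measured compounds shown here, the only measured step bearing on this, an at least 11-fold lower number from compound 1 to compound 2 (1.04 log units; beyond the scatter), also replaced the 3-methylphenyl with a chlorine-bearing phenyl and was large. A step of similar direction is therefore expected, an at least 6.6-fold lower number from compound 1 to compound 3 (0.82 log units; beyond the scatter), with wide uncertainty. Compound 3 is estimated at 15000 nM, between 4000 nM and 60000 nM.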

Compound 3, half-maximal inhibitory concentration: 26400 nM
The estimate for compound 3 lay 1.8-fold (0.25 log units) below the measured number; the range from low to high includes it.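

The 2,3-dichlorophenyl group also improves on 3-methylphenyl at this carbon, with an at least 3.7-fold lower number from compound 1 to compound 3 (0.57 log units; beyond the scatter), so the gain is not confined to compound 2. The value for compound 1 is only a limit: the limit of > 100000 nM in this assay, at which 1 of the 3 values shown sits. The two chlorine-bearing groups are not interchangeable, since this change gives a 2.9-fold higher number from compound 2 to compound 3 (0.47 log units; beyond the scatter), so which halogens the phenyl carries, and where, affects the number.

From the compounds shown here alone, whether an unsubstituted phenyl, or a phenyl carrying an amine or a carboxylic acid, would give a lower number than compound 2 remains open.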